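This account rests on a few compounds, and the source may have more. Where it says the series, first, only, none or still open, it means among the compounds named here.

Working notes on the series in an assay on BTI cells for inhibition of Amine oxidase [flavin-containing] B (Homo sapiens), read by fluorescence and Amplex Red, with a stated time of 15 min; a higher number here means a weaker inhibitor, a lower number a stronger inhibitor.

The three measured compounds share one core and differ only in the aryl group on the carbon with a double bond to nitrogen. Compound 1 `CC(=O)N1N=C(c2ccccc2C)OC1c1ccc(Cl)c(Cl)c1` gives 2460 nM in this assay. Compound 2 `CC(=O)N1N=C(c2ccc(Br)cc2)OC1c1ccc(Cl)c(Cl)c1` gives 67.7 nM, and the change is a 36-fold lower number from compound 1 to compound 2 (1.56 log units; beyond the scatter). Compound 3 `CC(=O)N1N=C(c2ccc([N+](=O)[O-])cc2)OC1c1ccc(Cl)c(Cl)c1` gives 9.46 nM, a change of a 7.2-fold lower number from compound 2 to compound 3 (0.85 log units; beyond the scatter). Compound 3 therefore stands lowest of the three numbers; its nearest neighbour is compound 2, and compound 1 lies furthest from it.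

Compound 4 `COc1ccc(C2=NN(C(C)=O)C(c3ccc(Cl)c(Cl)c3)O2)cc1` has not yet been measured in this assay. It differs from compound 3 in one place: methoxy in place of nitro on an aromatic carbon. Both measured steps bear on this change, since each alters the substituent on this same aryl ring, and both were beyond the scatter, the first large and the second modest. Of the three substituents measured, nitro gave the lowest number, so taking it away is expected to move the number upward rather than downward. A rise of about the size seen between compound 2 and compound 3 seems a fair expectation. The expected step for compound 4 is an 11-fold higher number from compound 3 to compound 4 (1.02 log units; beyond the scatter). The estimate for compound 4 is 100 nM, with a range from 25 nM to 400 nM.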

Compound 4, half-maximal inhibitory concentration: 218 nM
For compound 4 the middle estimate is 2.2-fold (0.34 log units) below the measured one, and the stated range covers the measured number.
By their numbers in this assay, from the lowest: compound 3; then compound 2; then compound 4; then compound 1.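

In this assay, the step of a 23-fold higher number from compound 3 to compound 4 (1.36 log units; beyond the scatter) shows that the aromatic carbon para to a large group responds strongly to exchanging nitro for methoxy, and that this exchange costs more than the earlier change from bromo to nitro gained. The step of a 3.2-fold higher number from compound 2 to compound 4 (0.51 log units; beyond the scatter) places methoxy above bromo as well, giving an order of nitro, bromo, methoxy from the lowest number upward at this position, while an 11-fold lower number from compound 1 to compound 4 (1.05 log units; beyond the scatter) shows that the 4-methoxyphenyl group, the highest of the three at this position, still stays well below the 2-methylphenyl group. No measurement at hand accounts for this order or for the size of these steps.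

From the compounds shown here alone, it remains open where an amine, a nitrile or a carboxylic acid on the same carbon would fall relative to nitro and methoxy, and so whether nitro marks the low end of the range at this position. Going by these compounds, it is also open whether the same order would hold if the two chlorines on the other aryl group were replaced, for example by a single fluorine.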